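Piperidine in place of pyridine at the para position

A few compounds are considered here, and "the series" means these few. Any claim that something is new, unique, unknown or untested is made for them only; others in the source may bear on it.

Measured so far:
compound 1, `CCOc1ccc(NC(=O)CSc2nc3c(c(=O)n2-c2ccccc2)SCC3)cc1`, 1000 nM
compound 2, `O=C(CSc1nc2c(c(=O)n1-c1ccccc1)SCC2)Nc1ccc(-c2cccs2)cn1`, 0.3 nM
compound 3, `O=C(CSc1nc2c(c(=O)n1-c1ccccc1)SCC2)Nc1ccc(-c2cccnc2)cc1`, 0.45 nM

In an assay on L cells for inhibition of Protein-serine O-palmitoleoyltransferase porcupine (Mus musculus), read by reporter gene assay, with a stated time of 24 h (a higher number here means that more compound is needed for the effect, a lower number that less compound is needed), compound 3 stands second highest of the three numbers; its nearest neighbour is compound 2, within the scatter, and its furthest is compound 1. For the measured compounds named here, the only single-point step measured, a 2200-fold lower number from compound 1 to compound 3 (3.35 log units; beyond the scatter), shows how strongly the group at this position can move this assay. Compound 4, `O=C(CSc1nc2c(c(=O)n1-c1ccccc1)SCC2)Nc1ccc(N2CCCCC2)cc1`, differs from compound 3 in one place: piperidin-1-yl in place of pyridin-3-yl on an aromatic carbon. Going by the values given here, no measured step swaps an aromatic ring for a non-aromatic one here, so the direction rests on the large swing seen for compound 1. A moderate rise is expected, a 22-fold higher number from compound 3 to compound 4 (1.35 log units; beyond the scatter), giving compound 4 an estimated 10 nM, between 1 nM and 100 nM.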

Compound 4, half-maximal effective concentration: 30 nM
Compound 4: the middle estimate sits 3.0-fold (0.48 log units) below what was measured; low and high end bracket the measured number.
By their numbers in this assay, from the lowest: compounds 2 and 3 (each within the scatter of the next); then compound 4; then compound 1.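

In this assay, piperidin-1-yl and pyridin-3-yl match in the counts printed for them, yet the change from the aromatic to the non-aromatic ring gives a 67-fold higher number from compound 3 to compound 4 (1.82 log units; beyond the scatter). So at this position, more than the size of the six-membered ring sets the number. The same piperidin-1-yl still gives a 33-fold lower number from compound 1 to compound 4 (1.52 log units; beyond the scatter), which places it in an intermediate position among the three groups compared here. No measurement here accounts for either step.

Open, going by these compounds, is how a morpholine, a piperazine or a plain phenyl ring would compare at this aromatic carbon.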